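Methoxycarbonyl to hydroxymethyl on the shared core

The source may report more compounds than this note shows. Statements on the series, on what has been measured and on what is new or still open speak of the compounds shown alone.

For the measured compounds named here, in a functional assay on MCF7S cells (Homo sapiens) (on this read-out higher numbers stand for weaker inhibition of growth and lower numbers for stronger inhibition of growth), compound 2 `COC(=O)/C=C\[C@H]1OCCC[C@@H]1O[Si](C)(C)C(C)(C)C` gives 32000 nM, and compound 1 `CC(C)(C)[Si](C)(C)O[C@H]1CCCO[C@@H]1C/C=C/CO` gives 25000 nM; the only measured step, a 1.3-fold higher number from compound 1 to compound 2 (0.11 log units; within the scatter), lies within the scatter, so the two numbers cannot be ranked. Compound 3 `CC(C)(C)[Si](C)(C)O[C@H]1CCCO[C@@H]1/C=C\CO` differs from compound 2 by hydroxymethyl in place of methoxycarbonyl on a double-bonded chain carbon bound to a double-bonded chain carbon. Going by the values given here, the one step in hand, a 1.3-fold higher number from compound 1 to compound 2 (0.11 log units; within the scatter), also exchanged the methoxycarbonyl-bearing side chain for a hydroxy-bearing one and moved the number only within the scatter. The expected step is therefore a 1.1-fold lower number from compound 2 to compound 3 (0.06 log units; within the scatter), nothing beyond the scatter. Compound 3 is estimated at 28000 nM, range 11000 nM to 70000 nM.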

Compound 3, concentration for 50% growth inhibition: 6400 nM
Estimate against measurement, compound 3: 4.4-fold (0.64 log units) above, and the stated range ends above it.
By their numbers in this assay, from the lowest: compound 3; then compounds 1 and 2 (each within the scatter of the next).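

Hydroxymethyl in place of methoxycarbonyl on a double-bonded chain carbon bound to a double-bonded chain carbon gives, in this assay, the first change beyond the scatter in the series: a 5.0-fold lower number from compound 2 to compound 3 (0.70 log units; beyond the scatter). The shorter 3-hydroxyprop-1-en-1-yl chain also separates from 4-hydroxybut-2-en-1-yl, with a 3.9-fold lower number from compound 1 to compound 3 (0.59 log units; beyond the scatter), so a hydroxy-bearing chain alone does not set the number, since compound 1 stays within the scatter of compound 2. No evidence bears on the origin of these steps. Open, going by these compounds, is how a carboxylic acid or an aminomethyl group at this place would read, and whether the step persists on a longer chain.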